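Alkynyl deoxyuridines: chain end and growth inhibition

This account rests on a few compounds, and the source may have more. Where it says the series, first, only, none or still open, it means among the compounds named here.

Compound 2 `O=c1[nH]c(=O)n([C@H]2C[C@H](O)[C@@H](CO)O2)cc1C#CCCO` and compound 3 `O=c1[nH]c(=O)n([C@H]2C[C@H](O)[C@@H](CO)O2)cc1C#CCO` share a core; they differ by hydroxy in place of hydroxymethyl on a saturated chain carbon bound to a triple-bonded carbon. In a functional assay on L1210 cells (Mus musculus) (a lower number here means a stronger inhibitor, a higher number a weaker inhibitor), compound 2 gives only a limit, > 1000 ug/mL. Compound 3 likewise gives only a limit in this assay, > 1000 ug/mL. The step that the two limits leave unreadable from compound 2 to compound 3 therefore cannot be read. Compound 1 `CCCCC#Cc1cn([C@H]2C[C@H](O)[C@@H](CO)O2)c(=O)[nH]c1=O` arises from compound 2 by ethyl in place of hydroxy on a saturated chain carbon, two bonds along the chain from a triple-bonded carbon; in this assay compound 1 gives 1000 ug/mL, and the step of a number no higher from compound 2 to compound 1 (the limit leaves the size open) is bounded on one side only, since (the limit of > 1000 ug/mL in this assay, at which 2 of the 3 values shown sit). Compound 4 `CCCC#Cc1cn([C@H]2C[C@H](O)[C@@H](CO)O2)c(=O)[nH]c1=O` arises from compound 3 by ethyl in place of hydroxy on a saturated chain carbon bound to a triple-bonded carbon, the same kind of change, placed on a saturated chain carbon bound to a triple-bonded carbon rather than two bonds along the chain from one. Compound 1 at 1000 ug/mL is the only anchor. The step of a number no higher from compound 3 to compound 4 (the limit leaves the size open) is expected to be small. Compound 4 is estimated at 1000 ug/mL, between 300 ug/mL and 3000 ug/mL.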

Compound 4, concentration for 50% inhibition: > 1000 ug/mL
Compound 4 gave a limit, no number; the forecaster's own chance of this, stated with the estimate: 55%; the middle value lies on the limit itself.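

In this assay compound 4 gives only a limit, > 1000 ug/mL. The steps among compound 2, compound 3 and compound 4 cannot be read, including ethyl in place of hydroxy on a saturated chain carbon bound to a triple-bonded carbon, because each of these compounds gives only a limit: the limit of > 1000 ug/mL in this assay, at which 3 of the 4 values shown sit. The same kind of change further along the chain gives a number no higher from compound 2 to compound 1 (the limit leaves the size open), and the remaining comparison gives a number no lower from compound 1 to compound 4 (the limit leaves the size open), so carrying the change from one core to another is neither supported nor ruled out.

Going by these compounds, whether an amine or a carboxylic acid at the chain end, or a longer chain, would give a readable number in this assay stays open. Compound 1, at 1000 ug/mL, remains the only anchor.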